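Swapping cyano for nitro on an aromatic carbon

This account rests on a few compounds, and the source may have more. Where it says the series, first, only, none or still open, it means among the compounds named here.

Compound 1 `COC(=O)c1ccc(NCc2cncn2Cc2ccc(F)cc2)cc1-c1ccccc1`: "not determined" (no result reported)
Compound 2 `COC(=O)c1ccc(NCc2cncn2Cc2ccc(Br)cc2)cc1-c1ccccc1`: > 10000 nM (a limit of the assay)
Compound 3 `COC(=O)c1ccc(NCc2cncn2Cc2ccccc2C#N)cc1-c1ccccc1`: 25000 nM

Within the data shown here, in a toxicity assay on NIH3T3 cells (Mus musculus) for cytotoxicity, read by resazurin assay (on this read-out lower numbers stand for an effect already at smaller amounts and higher numbers for an effect only at larger amounts of compound), compound 3 gives 25000 nM as the only actual number in this small set. Compound 2 stands at > 10000 nM, which is a limit and not a number. Compound 1 has no reported result.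

Compound 4 `COC(=O)c1ccc(NCc2cncn2Cc2ccccc2[N+](=O)[O-])cc1-c1ccccc1` carries nitro in place of the cyano of compound 3 on an aromatic carbon, ortho to a large group: nitro in place of cyano on an aromatic carbon. Among the measured compounds shown here, the only measured step is a step that the limit leaves unreadable from compound 2 to compound 3, so it offers no size to carry over, and it is a different change. For the measured compounds named here, no measured step covers this swap, so no shift beyond the usual scatter is expected in this assay and no direction can be favoured. The starting point therefore remains compound 3 at 25000 nM. The expected step is a 1.1-fold lower number from compound 3 to compound 4 (0.06 log units; within the scatter). Compound 4 is estimated at 22000 nM, with an expected range from 9000 nM to 50000 nM.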

Compound 4, half-maximal effective concentration: 10000 nM
The estimate for compound 4 lay 2.2-fold (0.34 log units) above the measured number; the range from low to high includes it.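

In this assay, the position on an aromatic carbon ortho to a large group now shows its first readable step: with nitro in place of cyano there is a 2.5-fold lower number from compound 3 to compound 4 (0.40 log units; beyond the scatter). Among these compounds, this single change therefore moves the number, towards an effect at smaller amounts of compound, whereas the earlier compounds offered no step of readable size. Compound 2 stands at a limit and not a number, and its step to compound 3 cannot be read in size. There is also a number no higher from compound 2 to compound 4 (the limit leaves the size open), which likewise cannot be read in size: the limit of > 10000 nM in this assay, at which 1 of the 4 values shown sits.

On these data alone, it remains open how an amine, a carboxylic acid or a methoxy group on the same aromatic carbon would read in this assay. As far as these compounds go, whether nitro in place of cyano would give a similar step elsewhere on the ring also remains open, as this rests on one pair of compounds.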